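Chloro in Place of Methyl on Compound 3

This account rests on a few compounds, and the source may have more. Where it says the series, first, only, none or still open, it means among the compounds named here.

In a functional assay on CHO cells for antagonist activity at metabotropic glutamate receptor 5 (Rattus norvegicus), read by calcium flux (on this read-out lower numbers stand for stronger inhibition and higher numbers for weaker inhibition), compound 3 `Cc1cccc(-c2ccc3ccc(C)nc3n2)c1` gives 277 nM. Of the two numbers shown it is the higher, and its nearest neighbour is compound 1 `Cc1cccc(-c2ccc3cccnc3n2)c1`, which gives 225 nM; the step of a 1.2-fold higher number from compound 1 to compound 3 (0.09 log units; within the scatter) lies within the scatter. Compound 2 `Cc1cc(C)cc(-c2cnc3cccnc3c2)c1` reaches only a limit of this assay, > 30000 nM. Within the data shown here, the one measured step, methyl for hydrogen, therefore changed nothing beyond the scatter.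

Compound 4 `Cc1ccc2ccc(-c3cccc(Cl)c3)nc2n1` differs from compound 3 in one place: chloro in place of methyl on an aromatic carbon. Among the measured compounds shown here, no measured step covers a chloro for methyl exchange, so the expectation rests on the small size of the single step seen. The expected step of a 1.1-fold lower number from compound 3 to compound 4 (0.04 log units; within the scatter) is none beyond the scatter. Compound 4 is thus estimated at 250 nM, between 90 nM and 700 nM.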

Compound 4, half-maximal inhibitory concentration: 177 nM
Compound 4: the middle estimate sits 1.4-fold (0.15 log units) above what was measured; low and high end bracket the measured number.
By their numbers in this assay, from the lowest: compounds 4, 1 and 3 (each within the scatter of the next). At a limit, above all of these: compound 2.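

In this assay, among these compounds, the earlier step touched the core, whereas this one is the first change on the six-membered aromatic ring of carbon only, meta to a large group. There, chloro in place of methyl gives a 1.6-fold lower number from compound 3 to compound 4 (0.19 log units; within the scatter), so this place accepts either group without a change beyond the scatter. Nothing at hand gives a cause for this step.

From the compounds shown here alone, what stays open is whether the place tolerates groups of another kind. A nitrile, a methoxy group or an amine there could show that, as could a bare hydrogen.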